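Trifluoromethyl replacing carboxymethoxy on the pyridine of compound 2

The source may report more compounds than this note shows. Statements on the series, on what has been measured and on what is new or still open speak of the compounds shown alone.

Of the compounds shown here, three sharing one core have been tested in a functional assay on FaDu cells (Homo sapiens) for cytotoxicity, read by MTT assay, with a stated time of 72 h; a higher number here means that more compound is tolerated, a lower number that less compound is tolerated. Compound 3 `CCCCn1cc(C(=O)C(=O)Nc2ccc(OC)nc2)c2ccccc21`, with a methoxy on its pyridine and a butyl on its indole nitrogen, gives 18 nM in this assay. Compound 2 `COCCn1cc(C(=O)C(=O)Nc2ccc(OCC(=O)O)nc2)c2ccccc21` gives > 10000 nM, which is a limit of the assay rather than a number, so only an upper bound on its lethality is known; the same limit marks (the limit of > 10000 nM in this assay, at which 2 of the 3 values shown sit). Compound 1 `CC(C)n1cc(C(=O)C(=O)Nc2ccc(C(F)(F)F)nc2)c2ccccc21`, which also carries a trifluoromethyl on the pyridine, gives > 10000 nM in this assay, again a limit.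

The step now followed leads to compound 4 `COCCn1cc(C(=O)C(=O)Nc2ccc(C(F)(F)F)nc2)c2ccccc21`, which differs from compound 2 only by trifluoromethyl in place of carboxymethoxy on an aromatic carbon. With the limit of compound 1 sitting on the same trifluoromethyl pyridine, no step beyond the usual scatter is expected from compound 2 to compound 4, namely an at least 1.1-fold lower number from compound 2 to compound 4 (0.04 log units; that floor lies within the scatter). Compound 4 is therefore estimated at 9000 nM in this assay, in a range from 1500 nM to 40000 nM, with a fair chance that only a limit is reported.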

Compound 4, concentration lethal to 50% of the cells: > 10000 nM
Compound 4: only a limit was reported; the forecaster's own chance of this, stated with the estimate: 60%; middle value at least 1.1-fold (0.04 log units) away from the limit.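

The steps to compound 4 from compound 1 and from compound 2 cannot be read in this assay, because all three values are limits of the assay: the limit of > 10000 nM in this assay, at which 3 of the 4 values shown sit.

Left open is how far compound 1, compound 2 and compound 4 each lie past that limit, and so whether trifluoromethyl in place of carboxymethoxy changes the read-out at all.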